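Swapping the aryl group on the shared core

The source may report more compounds than this note shows. Statements on the series, on what has been measured and on what is new or still open speak of the compounds shown alone.

Two compounds share a fused two-ring core and differ in the groups attached to it. Compound 1 `COc1ccc(-n2cnc3cnc(-c4ccccc4OC(F)(F)F)cc32)cc1OC` is tested in a functional assay on HL-60 cells (Homo sapiens) for activation, read by flow cytometry, with a stated time of 4 days (on this read-out lower numbers stand for an effect already at smaller amounts and higher numbers for an effect only at larger amounts of compound), and gives 2500 nM. Compound 2 `Cc1cccc(C)c1-c1cc2c(cn1)ncn2-c1ccc(OC(F)F)cc1` gives 980 nM in the same this assay, the lower of the two numbers, and the gap to compound 1 is wider than the usual scatter. Going by the values given here, no single-point step between them can be drawn, since both attached groups differ.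

Compound 3 `Cc1cc(O)ccc1-c1cc2c(cn1)ncn2-c1ccc(OC(F)F)cc1` has not been measured. It keeps the whole of compound 2 except for one change on the six-membered aromatic ring of the core: 4-hydroxy-2-methylphenyl in place of 2,6-dimethylphenyl on an aromatic carbon. Among the compounds with values here, with no measured step of this kind to lean on, the expected step for compound 3 in this assay is modest and slightly toward a higher number, a 1.5-fold higher number from compound 2 to compound 3 (0.18 log units; within the scatter), within a wide range. Compound 3 is therefore estimated to give 1500 nM, between 400 nM and 6000 nM.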

Compound 3, half-maximal effective concentration: 890 nM
Estimate against measurement, compound 3: 1.7-fold (0.23 log units) above; the range from low to high includes it.
By their numbers in this assay, from the lowest: compounds 3 and 2 (each within the scatter of the next); then compound 1.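

In this assay, placing 4-hydroxy-2-methylphenyl in place of 2,6-dimethylphenyl on this aromatic carbon gives a 1.1-fold lower number from compound 2 to compound 3 (0.04 log units; within the scatter) and so leaves the two compounds indistinguishable on this read-out. The earlier compounds shown here offered no single-place step, and this one shows that this aromatic carbon can carry a ring with a hydroxy group, with one hydrogen-bond donor and one acceptor where the old group counted none, without a shift beyond the scatter. Nothing measured here explains why the number holds through this change.

The hydroxy group arrives together with the loss of a methyl group, so the compounds shown cannot separate these two changes. On these data alone, how an aminophenyl or a carboxyphenyl group would behave on this carbon in this assay also remains open.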